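Swapping a cyclopropyl for a methoxymethyl: expected cell tolerance

The compounds below may be only part of what the source reports. "The series", "measured", "known", "first", "only" and "open" are said of these compounds alone.

Compound 1 `C=CCN(c1ccc(Cl)cc1C)S(=O)(=O)c1cc(Cl)ccc1Cl`: in an ADME assay on A549 cells (Homo sapiens) for cytotoxicity, read by MTT assay (a higher number here means that more compound is tolerated, a lower number that less compound is tolerated), compound 1 gives > 5000 nM, which is a limit of the assay.
Compound 2 `C#CCN(c1ccc(Cl)cc1C)S(=O)(=O)c1cc(Cl)ccc1Cl`: in this assay compound 2 gives > 5000 nM, again a limit.
Compound 3 `Cc1cc(Cl)ccc1N(CC1CC1)S(=O)(=O)c1cc(Cl)ccc1Cl`: in this assay compound 3 gives > 5000 nM, also a limit.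

Compound 3 therefore stands where every measured compound stands, at the limit of > 5000 nM in this assay, at which 3 of the 3 values shown sit. Compound 4 `COCCN(c1ccc(Cl)cc1C)S(=O)(=O)c1cc(Cl)ccc1Cl` differs from it in one place: methoxymethyl in place of cyclopropyl on a saturated chain carbon bound to a sulfonamide nitrogen. Within the data shown here, the steps that touch this position, a step that the two limits leave unreadable from compound 1 to compound 3 and a step that the two limits leave unreadable from compound 2 to compound 3, cannot be sized, and no measured step involves a methoxymethyl. There is thus no reading that points to a change beyond the scatter. Compound 4 is expected to give 8000 nM (range 4000 nM to 20000 nM). The step that the limit leaves unreadable from compound 3 to compound 4 is estimated to stay within the scatter, most likely as another limit.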

Compound 4, half-maximal cytotoxic concentration: > 5000 nM
Compound 4 was reported as a limit; the forecaster's own chance of this, stated with the estimate: 85%; the middle value does not contradict the limit.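

Among these compounds, no step between compound 1, compound 2, compound 3 and compound 4 can be read, since each value is only a limit: the limit of > 5000 nM in this assay, at which 4 of the 4 values shown sit. On these data alone, whether these four side chains differ at all in this assay stays open.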